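Removing a terminal chloro from a carbamate side chain

A few compounds are considered here, and "the series" means these few. Any claim that something is new, unique, unknown or untested is made for them only; others in the source may bear on it.

Compound 1 `O=C(c1ccccc1)c1ccc(NC(=O)c2cc(Cl)ccc2O)cc1`: 48000 nM
Compound 2 `O=C(NCCCCl)Oc1ccc(Cl)cc1C(=O)Nc1ccc(C(=O)c2ccccc2)cc1`: 16100 nM

In an ADME assay on MONO-MAC-6 cells (Homo sapiens) for cytotoxicity, read by MTT assay, with a stated time of 16 h (on this read-out higher numbers stand for weaker inhibition and lower numbers for stronger inhibition), compound 2 stands lowest of the two numbers. Within the data shown here, the only measured step is a 3.0-fold lower number from compound 1 to compound 2 (0.47 log units; beyond the scatter), which concerns adding the whole carbamate group, not altering it.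

Compound 3 `CCCNC(=O)Oc1ccc(Cl)cc1C(=O)Nc1ccc(C(=O)c2ccccc2)cc1` differs from compound 2 by hydrogen in place of chloro on a saturated chain carbon, three bonds along the chain from an amide-type nitrogen. Among the measured compounds shown here, no measured step bears on this change, so there is no basis for expecting a step beyond the scatter in this assay in either direction. Compound 3 is therefore estimated at 20000 nM, within a range of 8000 nM to 50000 nM. This expectation corresponds to a 1.2-fold higher number from compound 2 to compound 3 (0.09 log units; within the scatter).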

Compound 3, half-maximal inhibitory concentration in the MONO-MAC-6 assay: 18700 nM
Beside the measured number, compound 3's estimate is 1.1-fold (0.03 log units) above it; low and high end bracket the measured number.
By their numbers in the MONO-MAC-6 assay, from the lowest: compounds 2 and 3 (each within the scatter of the next); then compound 1.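

In the MONO-MAC-6 assay the terminal chloro of the 3-chloropropyl group turns out to make no readable difference: there is a 1.2-fold higher number from compound 2 to compound 3 (0.07 log units; within the scatter) on going to propyl. The gain from the carbamate therefore survives without the chloro, with a 2.6-fold lower number from compound 1 to compound 3 (0.41 log units; beyond the scatter) when propylcarbamoyl stands in place of hydrogen on the oxygen on the aromatic ring. In a physicochemical assay for solubility, read by spectrophotometry (on this read-out higher numbers stand for higher solubility and lower numbers for lower solubility), compound 2 gives a limit of the assay, not a number: < 50000 nM. In the physicochemical assay compound 3 likewise gives a limit of the assay, not a number: < 50000 nM. In the physicochemical assay the step from compound 2 to compound 3 cannot be read, because both compounds sit at a limit of the assay: the limit of < 50000 nM in the physicochemical assay, at which 2 of the 2 values shown sit.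

On these data alone, whether an amine or a carboxylic acid at the chain end, or a longer chain, would shift the number in the MONO-MAC-6 assay stays open.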